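Dichlorobenzimidazole series: methyl to trifluoromethyl on the benzyl ring

The compounds below may be only part of what the source reports. "The series", "measured", "known", "first", "only" and "open" are said of these compounds alone.

Compound 1 `Cc1cccc(Cn2c(N)nc3cc(Cl)c(Cl)cc32)c1` gives 65000 nM in a functional assay on KB cells (Homo sapiens) for inhibition; on this read-out higher numbers stand for weaker inhibition and lower numbers for stronger inhibition. Compound 2 `Nc1nc2cc(Cl)c(Cl)cc2n1Cc1cccc(C(F)(F)F)c1` carries the change trifluoromethyl in place of methyl on an aromatic carbon and in this assay gives 45000 nM, a step of a 1.4-fold lower number from compound 1 to compound 2 (0.16 log units; within the scatter). Compound 3 `Cc1cccc(Cn2c(Cl)nc3cc(Cl)c(Cl)cc32)c1` differs from compound 1 by chloro in place of amino on an aromatic carbon, which is how the two cores differ. In this assay compound 3 gives only a limit, > 100000 nM, not a number. The step of an at least 1.5-fold higher number from compound 1 to compound 3 (0.18 log units; that floor lies within the scatter) therefore rests on (the limit of > 100000 nM in this assay, at which 1 of the 3 values shown sits).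

Compound 4 `FC(F)(F)c1cccc(Cn2c(Cl)nc3cc(Cl)c(Cl)cc32)c1` is not yet measured. It differs from compound 3 by trifluoromethyl in place of methyl on an aromatic carbon, the same change that leads from compound 1 to compound 2, on the same place in both pairs, but made on the core of compound 3 rather than that of compound 1. The expected step is a step that the limit leaves unreadable from compound 3 to compound 4, set beside the measured 1.4-fold lower number from compound 1 to compound 2 (0.16 log units; within the scatter), which stayed within the scatter. Since compound 3 sits at a limit, compound 4 may also return only a limit. Compound 4 is estimated at 110000 nM, expected between 45000 nM and 300000 nM.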

Compound 4, half-maximal inhibitory concentration: > 100000 nM
Compound 4 gave a limit, no number; the forecaster's own chance of this, stated with the estimate: 65%; the middle value lies beyond the limit too.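

In this assay, the step from methyl to trifluoromethyl on the core of compound 3 cannot be read, since compound 3 and compound 4 each stand at a limit, so nothing shows whether the change behaves there as it does on the core of compound 1. The one readable new step concerns chloro in place of amino on the trifluoromethyl side, an at least 2.2-fold higher number from compound 2 to compound 4 (0.34 log units; beyond the scatter), and it can be set beside the same change on the methyl side only with the comparison left open: the same change on two cores in this assay, an at least 1.5-fold higher number (0.18 log units; that floor lies within the scatter) from compound 1 to compound 3 and an at least 2.2-fold higher number (0.34 log units; beyond the scatter) from compound 2 to compound 4; the limit leaves it open whether they differ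

The series therefore gives a floor for this step on each core, not a size, and no measure of how the trifluoromethyl change carries from one core to the other: the limit of > 100000 nM in this assay, at which 2 of the 4 values shown sit.

Open, going by these compounds, is whether a nitrile or a methoxy group in place of trifluoromethyl on the aromatic carbon would shift the values on the amino core. Also open, on these data alone, is whether a carboxylic acid or a longer chain in place of amino or chloro on the core would give a number rather than a limit.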